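Thiourea in place of benzyl at the ring nitrogen

The source may hold more compounds than are shown below. What is called first, only, known or untested is meant among the compounds shown, and "the series" means these compounds.

Compound 1 `NC(=O)c1c(NC(=O)c2ccccc2Cl)sc2c1CCN(Cc1ccccc1)C2` stands second highest of the three numbers in a functional assay on HL-60 cells (Homo sapiens) for antiproliferative activity, with a stated time of 24 h (on this read-out higher numbers stand for weaker inhibition and lower numbers for stronger inhibition), where compound 1 gives 12000 nM. Going by the values given here, compound 2 `Cc1ccc(C(=O)Nc2sc3c(c2C(N)=O)CCN(Cc2c(Cl)cccc2Cl)C3)cc1` gives 10000 nM and compound 3 `Cc1ccc(C(=O)Nc2sc3c(c2C(N)=O)CCN(Cc2ccc(Cl)cc2Cl)C3)cc1` gives 19900 nM; the only single-point step, a 2.0-fold higher number from compound 2 to compound 3 (0.30 log units; within the scatter), stays within the scatter. Compound 4 `NC(=O)c1c(NC(=O)c2ccccc2Cl)sc2c1CCN(C(=S)Nc1ccccc1)C2` differs from compound 1 by a group of 9 heavy atoms (7 carbon, 1 nitrogen, 1 sulfur; one six-membered aromatic ring of carbon only) in place of a group of 7 heavy atoms (7 carbon; one six-membered aromatic ring of carbon only), on an amine nitrogen in a ring. Among the compounds with values here, no measured step bears on this change: the step from compound 2 to compound 3 alters only the chlorine pattern of the benzyl, and nothing shows what exchanging the benzyl itself does. Since all three numbers lie within the scatter of each other, no step beyond the scatter is expected, no change at the digits printed from compound 1 to compound 4 (within the scatter). Compound 4 is therefore estimated at 12000 nM, with a range from 4000 nM to 36000 nM.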

Compound 4, half-maximal inhibitory concentration: 5940 nM
Compound 4: middle estimate off by 2.0-fold (0.31 log units), on the high side; the measured number falls inside the stated range.
By their numbers in this assay, from the lowest: compounds 4, 2, 1 and 3 (each within the scatter of the next, the first and the last beyond it).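

Going by these compounds alone, at the amine nitrogen in a ring, the benzyl is not required for activity in this assay: the thiourea group gives a 2.0-fold lower number from compound 1 to compound 4 (0.31 log units; beyond the scatter), a modest change and the first step beyond the scatter. Within the data shown here, earlier, the only step altered the chlorine pattern on the benzyl and stayed within the scatter. No supporting data explain the shift.

Open, going by these compounds, is whether the sulfur matters, which a urea with oxygen in its place would test. Also open, on these data alone, is whether the phenyl on the thiourea contributes, which a methyl thiourea would test.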